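Shifting the vinylcarbonylamino substituent on the shared core

A few compounds are considered here, and "the series" means these few. Any claim that something is new, unique, unknown or untested is made for them only; others in the source may bear on it.

Measured compounds:
compound 1 `C=CC(=O)Nc1ccc(Cn2nc(-c3ccc(Oc4ccccc4)cc3)cc2C(=O)O)cc1` > 60000 nM
compound 2 `C=CC(=O)Nc1ccc(Cn2nc(-c3ccc(Oc4ccccc4)cc3)cc2CO)cc1` 8000 nM

Compound 1 carries a carboxy group, and in a functional assay on JeKo-1 cells (Homo sapiens) for inhibition, read by luminescence and CellTiter-Glo, with a stated time of 72 h (on this read-out lower numbers stand for stronger inhibition and higher numbers for weaker inhibition), compound 1 reaches only > 60000 nM, a limit of the assay rather than a number. Compound 2, which has hydroxymethyl in place of carboxy, gives 8000 nM. That one step, an at least 7.5-fold lower number from compound 1 to compound 2 (0.87 log units; beyond the scatter), is the only one measured, and it concerns a different part of the molecule. Compound 3 `C=CC(=O)Nc1cccc(Cn2nc(-c3ccc(Oc4ccccc4)cc3)cc2C(=O)O)c1` keeps the carboxy group of compound 1 and differs from it only by 3-((vinylcarbonyl)amino)phenyl in place of 4-((vinylcarbonyl)amino)phenyl on a saturated chain carbon bound to an aromatic nitrogen. Going by the values given here, no measured step bears on this change, so the data give no direction for it beyond the scatter, and compound 1 offers only a limit of > 60000 nM in this assay, at which 1 of the 2 values shown sits, as a starting point. Compound 3 is therefore expected to stay near that limit, with an estimate of 60000 nM (range 15000 nM to 200000 nM), the step of a number no higher from compound 1 to compound 3 (the limit leaves the size open) being expected to fall within the scatter.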

Compound 3, half-maximal inhibitory concentration: > 60000 nM
Compound 3 was reported as a limit; the forecaster's own chance of this, stated with the estimate: 70%; the middle value lies on the limit itself.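

Compound 1 and compound 3 are both reported only as limits of the assay, not as numbers, and the step between them cannot be read. The compounds shown leave open whether 3-((vinylcarbonyl)amino)phenyl in place of 4-((vinylcarbonyl)amino)phenyl changes inhibition at all, including when hydroxymethyl replaces carboxy.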